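Chloro for fluoro on the N-aryl ring of compound 3

The source may hold more compounds than are shown below. What is called first, only, known or untested is meant among the compounds shown, and "the series" means these compounds.

Measured compounds:
compound 1, `Cc1ccc(-n2nc(-c3ccc(C(F)(F)F)cc3O)nc2-c2ccccc2O)cc1`, 71.5%
compound 2, `Oc1cc(C(F)(F)F)ccc1-c1nc(-c2ccccc2O)n(-c2ccccc2C(F)(F)F)n1`, 71%
compound 3, `Oc1cc(C(F)(F)F)ccc1-c1nc(-c2ccccc2O)n(-c2cccc(F)c2)n1`, 67.2%

The three measured compounds share one core and differ only in the aryl group on the aromatic nitrogen. In a functional assay on PC-12 cells (Rattus norvegicus) for cytotoxicity, read by MTT assay, with stated times of 2 h and 24 h, tested at 1 uM (a higher number here means a stronger effect of the compound at the concentration tested, a lower number a weaker effect), compound 1 gives 71.5%, compound 2 gives 71% and compound 3 gives 67.2%. Every step among them is small: a number 0.5 percentage points lower from compound 1 to compound 2 (within the scatter), a number 4.3 percentage points lower from compound 1 to compound 3 (within the scatter) and a number 3.8 percentage points lower from compound 2 to compound 3 (within the scatter). Compound 3 therefore stands together with the other two inside the scatter, and no ordering among the three can be read from these numbers.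

Compound 4, `Oc1cc(C(F)(F)F)ccc1-c1nc(-c2ccccc2O)n(-c2cccc(Cl)c2)n1`, is not yet measured. It differs from compound 3 by chloro in place of fluoro on an aromatic carbon. Among the compounds with values here, no measured step swaps one halogen for another on this ring, so the closest guidance is that three different aryl groups on the aromatic nitrogen all gave numbers within the scatter of one another in this assay. The expected step is accordingly none beyond the scatter: a number 1.8 percentage points higher from compound 3 to compound 4 (within the scatter). Compound 4 is estimated at 69%, with a range from 58% to 80%.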

Compound 4, a percentage reported as activity, at one concentration (the size of the read-out at that concentration, not a potency): 72.3%
Beside the measured number, compound 4's estimate is 3.3 percentage points below it; the measured number falls inside the stated range.
By their numbers in this assay, from the lowest: compounds 3, 2, 1 and 4 (each within the scatter of the next).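

In this assay, the only halogen swap shown on this ring, chloro in place of fluoro on an aromatic carbon meta to a large group, stays inside the scatter (a number 5.1 percentage points higher from compound 3 to compound 4 (within the scatter)). The 3-chlorophenyl group also stands within the scatter of the 2-(trifluoromethyl)phenyl group (a number 1.3 percentage points higher from compound 2 to compound 4 (within the scatter)) and the 4-methylphenyl group (a number 0.8 percentage points higher from compound 1 to compound 4 (within the scatter)), so all four aryl groups on the aromatic nitrogen now fall together, and a change of halogen on this ring adds no separation among them. No measurement at hand bears on why these numbers fall together.

The compounds shown leave open whether any group on this aryl ring can move the number beyond the scatter. What an amine or a carboxylic acid on this ring would give remains an open question.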